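The source may hold more compounds than are shown below. What is called first, only, known or untested is meant among the compounds shown, and "the series" means these compounds.

Measured compounds in a functional assay on WI-38 VA13 cells (Homo sapiens) for cytotoxicity; on this read-out higher numbers stand for an effect only at larger amounts of compound and lower numbers for an effect already at smaller amounts:
compound 1 `CC(=O)Nc1ccc2nc(NC(=O)C3CCCCC3)sc2c1`: 2.7 ug/mL
compound 2 `Cc1[nH][n+](C)c(C)c1C(=O)Nc1ccc2nc(NC(=O)C3CCCCC3)sc2c1`: 0.012 ug/mL
compound 3 `O=C(O)CCC(=O)Nc1nc2ccc(NC(=O)c3c(Cl)cccc3Cl)cc2s1`: > 6.6 ug/mL, a limit of the assay rather than a number

Compound 3 stands at the limit of > 6.6 ug/mL in this assay, at which 1 of the 3 values shown sits; of its position no more is known than that. Within the data shown here, the one step measured, a 230-fold lower number from compound 1 to compound 2 (2.35 log units; beyond the scatter), concerns the carbonyl carbon on the other side of the shared core and leaves the side changed here untouched, so it gives no direct reading on the present step.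

Compound 4 `CCCCNC(=O)Nc1nc2ccc(NC(=O)c3c(Cl)cccc3Cl)cc2s1` differs from compound 3 by butylamino in place of 2-carboxyethyl on a carbonyl carbon. Among the measured compounds shown here, no measured step covers this change; the expectation therefore rests on compound 3 alone and on the fact that it gave only a limit. No step beyond the scatter is expected in this assay in either direction, and a further limit is about as likely as a number.

For compound 4 the estimate is 6 ug/mL, within 1.5 ug/mL to 25 ug/mL, which means an expected step of an at least 1.1-fold lower number from compound 3 to compound 4 (0.04 log units; that floor lies within the scatter).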

Compound 4, half-maximal effective concentration: 0.028 ug/mL
Compound 4: middle estimate off by 210-fold (2.33 log units), on the high side, outside the stated range (below it).
By their numbers in this assay, from the lowest: compound 2; then compound 4; then compound 1. At a limit, above all of these: compound 3.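

In this assay, the carbonyl carbon changed here proves to be a place where the read-out responds strongly: butylamino in place of 2-carboxyethyl gives an at least 230-fold lower number from compound 3 to compound 4 (2.37 log units; beyond the scatter). Among these compounds, the only earlier step beyond the scatter concerned the carbonyl carbon on the other side of the shared core, so this is the first reading on this side. The size of the step is only a floor, since compound 3 stands at a limit: the limit of > 6.6 ug/mL in this assay, at which 1 of the 4 values shown sits.

The compounds shown do not separate the loss of the carboxylic acid from the entry of the butylamino group, and a pentyl group or a butylamino chain carrying a carboxylic acid on this carbonyl carbon would tell the two apart. As far as these compounds go, whether a shorter or longer alkylamino chain keeps the value of compound 4 also stays open.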